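From 3-bromophenyl to 1H-benzimidazol-2-yl on the sulfur chain

A few compounds are considered here, and "the series" means these few. Any claim that something is new, unique, unknown or untested is made for them only; others in the source may bear on it.

Among the measured compounds shown here, in a functional assay on PC-9 cells (Homo sapiens) for inhibition, read by MTT assay, with a stated time of 72 h (a lower number here means a stronger inhibitor, a higher number a weaker inhibitor), compound 1 `Cc1cc(Nc2cc(-c3ccccc3)[nH]n2)n2nc(SCC(=O)c3ccccc3)nc2n1` gives 4450 nM and compound 2 `Cc1cc(Nc2cc(-c3ccccc3)[nH]n2)n2nc(SCc3cccc(Br)c3)nc2n1` gives 8900 nM, so compound 2 stands within the scatter of the only other measured compound. Compound 3 `Cc1cc(Nc2cc(-c3ccccc3)[nH]n2)n2nc(SCc3nc4ccccc4[nH]3)nc2n1` differs from compound 2 by 1H-benzimidazol-2-yl in place of 3-bromophenyl on a saturated chain carbon bound to a sulfur, with 1H-benzimidazol-2-yl in place of 3-bromophenyl on a saturated chain carbon bound to a sulfur. For the measured compounds named here, the one measured step at this place, a 2.0-fold higher number from compound 1 to compound 2 (0.30 log units; within the scatter), stayed within the scatter, so no larger change is expected here. The expected change is a 1.5-fold lower number from compound 2 to compound 3 (0.17 log units; within the scatter), which is no step beyond the scatter. For compound 3 the estimated value is 6000 nM, with an expected range of 2000 nM to 18000 nM.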

Compound 3, half-maximal inhibitory concentration: 4840 nM
Estimate against measurement, compound 3: 1.2-fold (0.09 log units) above, within the range that was stated.
By their numbers in this assay, from the lowest: compounds 1, 3 and 2 (each within the scatter of the next).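

In this assay the entry of 1H-benzimidazol-2-yl gives a 1.8-fold lower number from compound 2 to compound 3 (0.26 log units; within the scatter) and, measured against benzoyl, a 1.1-fold higher number from compound 1 to compound 3 (0.04 log units; within the scatter) and so neither step leaves the scatter. On a saturated chain carbon bound to a sulfur, a group with two rings and a hydrogen-bond donor is thus exchanged for 3-bromophenyl or benzoyl with no step beyond the scatter. Nothing available accounts for this result. On these data alone, whether an amine, a carboxylic acid or a longer chain at this place would produce a step beyond the scatter remains open.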